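The source may hold more compounds than are shown below. What is called first, only, known or untested is meant among the compounds shown, and "the series" means these compounds.

Working notes on the hydrazone series.

Compound 1 `Cc1csc(N/N=C/c2ccc(Cl)cc2Cl)n1` gives 17 nM in an assay on mitochondria for inhibition of Amine oxidase [flavin-containing] B (Bos taurus); a lower number here means a stronger inhibitor, a higher number a weaker inhibitor. Compound 2 `Clc1ccc(/C=N/Nc2nc(-c3ccccc3)cs2)c(Cl)c1`, in this assay, gives 132 nM. The change from compound 1 to compound 2, (phenyl in place of methyl on an aromatic carbon), produced a 7.8-fold higher number from compound 1 to compound 2 (0.89 log units; beyond the scatter). Compound 3 `COc1ccc(/C=N/Nc2nc(C)cs2)cc1` gives 4.07 nM in this assay, the lowest of the three numbers; the difference between the core of compound 3 and the core of compound 1 is not broken down here.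

Compound 4 `COc1ccc(/C=N/Nc2nc(-c3ccccc3)cs2)cc1` has not yet been measured in this assay. It differs from compound 3 by phenyl in place of methyl on an aromatic carbon, the same change that took compound 1 to compound 2, at the same place. On that basis the step is expected to fall in the same direction and of a similar size, so for compound 4 a step of a 6.1-fold higher number from compound 3 to compound 4 (0.79 log units; beyond the scatter) is estimated, resting on compound 2 having given 132 nM after the same change. Compound 4 is accordingly expected to give about 25 nM in this assay, with the range 8 nM to 80 nM allowing for the change to play out somewhat differently on the core of compound 3. The measured value for compound 4 follows.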

Compound 4, inhibition constant: 132 nM
Compound 4: the middle estimate sits 5.3-fold (0.72 log units) below what was measured; the whole stated range lies below it.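

Phenyl in place of methyl on an aromatic carbon gives a higher number on both cores in this assay, and on the core of compound 3 it gives a 32-fold higher number from compound 3 to compound 4 (1.51 log units; beyond the scatter). The direction of the change carries from one core to the other, but its size does not: the same change on two cores in this assay, a 7.8-fold higher number (0.89 log units; beyond the scatter) from compound 1 to compound 2 and a 32-fold higher number (1.51 log units; beyond the scatter) from compound 3 to compound 4, 4.2-fold (0.62 log units) apart, beyond the scatter of two such steps. This comparison rests on two cores only, so it gives no rule for the size of the step on a further core and does not show what sets that size.

On these data alone, it remains open whether the larger step goes with the methoxy group of compound 3 or would appear with other groups on that part of the core, such as a hydroxyl or a single fluorine. Also open, as far as these compounds go, is how this assay would respond to an ethyl group, an amine or a carboxylic acid in place of methyl at this ring carbon.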